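Fluoro to Methyl on the Benzyl Ring of Compound 1

The compounds below may be only part of what the source reports. "The series", "measured", "known", "first", "only" and "open" are said of these compounds alone.

Three compounds have so far been measured in a functional assay on SMMC-7721 cells (Homo sapiens) for cytotoxicity, read by MTT assay, with a stated time of 72 h; a lower number here means a stronger inhibitor, a higher number a weaker inhibitor:

compound 1 `CCNC(=O)N1CCN(C(=S)SCc2cn(Cc3ccc(F)cc3)nn2)CC1` gives 44400 nM
compound 2 `CC(C)NC(=O)N1CCN(C(=S)SCc2cn(Cc3ccc(F)cc3)nn2)CC1` gives 5970 nM
compound 3 `CCN(C)C(=O)N1CCN(C(=S)SCc2cn(Cc3ccc(F)cc3)nn2)CC1` gives 23700 nM

Compound 1 stands at the highest number of the three. Its nearest neighbour is compound 3, reached by a 1.9-fold lower number from compound 1 to compound 3 (0.27 log units; within the scatter), and its furthest is compound 2, reached by a 7.4-fold lower number from compound 1 to compound 2 (0.87 log units; beyond the scatter). Between the other two the step is a 4.0-fold higher number from compound 2 to compound 3 (0.60 log units; beyond the scatter).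

Compound 4 `CCNC(=O)N1CCN(C(=S)SCc2cn(Cc3ccc(C)cc3)nn2)CC1` is the next compound, and it differs from compound 1 only on the benzyl ring: methyl in place of fluoro on an aromatic carbon. Every step measured so far sits at the amide-type nitrogen end of the shared core, and none of them touches the benzyl ring, so none of them bears directly on this change. With nothing in the measured steps to point either way, compound 4 is expected to fall close to compound 1, with no step beyond the scatter; the expected step is a 1.0-fold lower number from compound 1 to compound 4 (0.00 log units; within the scatter). On that basis compound 4 is estimated at 44000 nM, with a range from 15000 nM to 130000 nM.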

Compound 4, half-maximal inhibitory concentration: > 128000 nM
Compound 4 ended at the assay's limit (the forecaster's own chance of this, stated with the estimate: 10%); middle value at least 2.9-fold (0.46 log units) away from the limit.
By their numbers in this assay, from the lowest: compound 2; then compounds 3 and 1 (each within the scatter of the next). At a limit, above all of these: compound 4.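

Among the compounds shown here, the earlier steps all changed the amide-type nitrogen end of the shared core, and this is the first to show that the benzyl ring also matters in this assay: 4-methylbenzyl in place of 4-fluorobenzyl gives an at least 2.8-fold higher number from compound 1 to compound 4 (0.45 log units; beyond the scatter). The value of compound 4 is a limit of the assay and not a number, so the step sets only a minimum size: the limit of > 128000 nM in this assay, at which 1 of the 4 values shown sits. Fluoro and methyl are therefore not interchangeable at this position, even though each is one heavy atom with no hydrogen-bond donor or acceptor.

On these data alone, whether other groups on this aromatic carbon, such as chloro, methoxy or plain hydrogen, would stay near compound 1 or follow compound 4 remains open. Also open, as far as these compounds go, is whether methyl in place of fluoro would have a similar effect on compound 2, with its isopropylamino group.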